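Bromo replaces an aryl group on a cytotoxicity-clean series

The source may hold more compounds than are shown below. What is called first, only, known or untested is meant among the compounds shown, and "the series" means these compounds.

Of the compounds shown here, three sharing one core have been tested in an ADME assay on Raji cells (Homo sapiens) for cytotoxicity, read by CellTiter-Glo and resazurin assay, with a stated time of 72 h; on this read-out higher numbers stand for an effect only at larger amounts of compound and lower numbers for an effect already at smaller amounts. Compound 1 `CCOC(=O)CCCCCOc1cccc(CN(C(=O)c2ccc(-c3cccc4ccccc34)cc2)C(C)C)c1` gives only a limit there, > 26000 nM. Compound 2 `CCOC(=O)CCCCCOc1cccc(CN(C(=O)c2ccc(-c3ccoc3)cc2)C(C)C)c1` likewise gives only a limit in this assay, > 26000 nM. Compound 3 `CCOC(=O)CCCCCOc1cccc(CN(C(=O)c2ccc(-c3cc(OC)ccc3F)cc2)C(C)C)c1` also gives only a limit in this assay, > 26000 nM. The steps among them are therefore a step that the two limits leave unreadable from compound 1 to compound 2, a step that the two limits leave unreadable from compound 1 to compound 3 and a step that the two limits leave unreadable from compound 2 to compound 3; the three values all sit at the limit of > 26000 nM in this assay, at which 3 of the 3 values shown sit, so compound 3 stands nowhere distinguishable from its neighbours on the numbers shown.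

Compound 4 `CCOC(=O)CCCCCOc1cccc(CN(C(=O)c2ccc(Br)cc2)C(C)C)c1` has not yet been measured in this assay. It differs from compound 3 thus: bromo in place of 2-fluoro-5-methoxyphenyl on an aromatic carbon. The measured steps bearing on it are the aryl-for-aryl exchanges, all unreadable in size, so no step beyond the scatter can be predicted in either direction. The account therefore expects that compound 4 remains at the limit, and the step that the limit leaves unreadable from compound 3 to compound 4 is an estimate of no readable change. For compound 4 the estimate in this assay is 40000 nM, between 20000 nM and 100000 nM.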

Compound 4, half-maximal effective concentration: > 26000 nM
Compound 4: a limit, no number (the forecaster's own chance of this, stated with the estimate: 85%); the middle value is on the limit's open side.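

In this assay compound 4 gives only a limit, > 26000 nM, so its steps from compound 1, compound 2 and compound 3 cannot be read. All four compounds share one limit: the limit of > 26000 nM in this assay, at which 4 of the 4 values shown sit.

The compounds shown leave open whether exchanging the group at this aromatic carbon changes the read-out at all, since none of them gives a number.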